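Notes on compound 4, a cyclopentyl analogue of compound 2

A few compounds are considered here, and "the series" means these few. Any claim that something is new, unique, unknown or untested is made for them only; others in the source may bear on it.

Measured in a functional assay on NCI-H460 cells (Homo sapiens) for antiproliferative activity, read by CCK-8 assay, with a stated time of 72 h, tested at 2 uM; a higher number here means a stronger effect of the compound at the concentration tested, a lower number a weaker effect:
compound 1 `COC(CCn1cnc2c(NCc3ccc(C(=O)Nc4ccccc4N)cc3)nc(Cl)nc21)OC` gives 43.7%
compound 2 `CCCCn1cnc2c(Nc3cccc(Cl)c3)nc(NCOCc3ccc(/C=C/C(=O)Nc4ccccc4N)cc3)nc21` gives 25.7%
compound 3 `CC1CCN(c2nc(Cl)nc3c2ncn3Cc2ccc(/C=C/C(=O)Nc3ccccc3N)cc2)CC1` gives 8.24%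

Compound 2 stands second highest of the three numbers in this assay; compound 3 lies below it beyond the scatter, and compound 1 lies above it beyond the scatter. Compound 4 `Nc1ccccc1NC(=O)/C=C/c1ccc(COCNc2nc(Nc3cccc(Cl)c3)c3ncn(C4CCCC4)c3n2)cc1` differs from compound 2 in one place: cyclopentyl in place of butyl on an aromatic nitrogen. Within the data shown here, no pair of measured compounds differs in a single place, so no comparable step is known from the data. The change exchanges one small saturated group for another of similar size, and the expected step of a number 2.3 percentage points higher from compound 2 to compound 4 (within the scatter) in this assay is small, with no clear direction and likely within the scatter. Compound 4 is accordingly estimated at 28%, with a range from 12% to 45%.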

Compound 4, a percentage reported as inhibition, at one concentration (the size of the read-out at that concentration, not a potency): 37.1%
Beside the measured number, compound 4's estimate is 9.1 percentage points below it; the measured number falls inside the stated range.
By their numbers in this assay, from the lowest: compound 3; then compound 2; then compounds 4 and 1 (each within the scatter of the next).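

Among these compounds, at this aromatic nitrogen, the group matters in this assay: cyclopentyl in place of butyl gives a number 11.4 percentage points higher from compound 2 to compound 4 (beyond the scatter) as a modest step, the first single-place comparison. Closing the substituent into a five-membered carbon ring is therefore compatible with a higher read-out at the concentration tested. No measured evidence bears on the reason for this step.

Going by these compounds, whether the ring or the added carbon carries the step remains open. So does how a cyclohexyl ring, a longer chain or a chain bearing an amine would read at this nitrogen.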